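From methylsulfonyl to methyl: one swap, one estimate

The source may hold more compounds than are shown below. What is called first, only, known or untested is meant among the compounds shown, and "the series" means these compounds.

Compound 1 `Cc1cccc(NC(=O)Nc2cccc(CNc3nccnc3Cl)c2)c1` gives 9570 nM
Compound 2 `CS(=O)(=O)c1ccc(NC(=O)Nc2cccc(CNc3nccnc3Cl)c2)cc1` gives 29300 nM

Both compounds were tested in a functional assay on T-24 cells (Homo sapiens) for antiproliferative activity, read by MTT assay, with a stated time of 48 h (a higher number here means a weaker inhibitor, a lower number a stronger inhibitor), and their numbers can be compared directly. Compound 2 at 29300 nM has the higher number of the two and so is the weaker inhibitor, while compound 1 at 9570 nM sits lower by more than the usual scatter. Compound 3 `Cc1ccc(NC(=O)Nc2cccc(CNc3nccnc3Cl)c2)cc1` has not yet been measured. Within the data shown here, it has methyl in place of methylsulfonyl on an aromatic carbon, para to a large group, and the swap methyl in place of methylsulfonyl on an aromatic carbon is its only difference from compound 2. Among the measured compounds shown here, no measured pair shows this change alone. Compound 1, which also carries a methyl group, gives 9570 nM in this assay and is the closest guide, so compound 3 is expected near that number. The expected move is a 2.9-fold lower number from compound 2 to compound 3 (0.47 log units; beyond the scatter) toward a stronger inhibitor, beyond the scatter. The estimated value for compound 3 is 10000 nM with a range from 4000 nM to 25000 nM for a single measurement.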

Compound 3, half-maximal inhibitory concentration: 9820 nM
Estimate against measurement, compound 3: 1.0-fold (0.01 log units) above; measured number inside the range.
By their numbers in this assay, from the lowest: compounds 1 and 3 (each within the scatter of the next); then compound 2.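

In this assay the change can now be read on its own: replacing methylsulfonyl with methyl on an aromatic carbon, para to a large group, gives a 3.0-fold lower number from compound 2 to compound 3 (0.47 log units; beyond the scatter) and so a stronger inhibitor. Shifting the methyl gives a 1.0-fold higher number from compound 1 to compound 3 (0.01 log units; within the scatter) with 4-methylphenyl in place of 3-methylphenyl on an amide-type nitrogen, so these two methyl placements cannot be told apart in this test. Nothing available here explains why the swap changes the number.

As far as these compounds go, whether an amine, a carboxylic acid or a longer chain such as ethyl at this position would give a number like that of compound 3 or like that of compound 2 remains open. This single pair also cannot show whether the same swap would give a similar step on a different core.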